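This account rests on a few compounds, and the source may have more. Where it says the series, first, only, none or still open, it means among the compounds named here.

In a functional assay (a higher number here means a weaker inhibitor, a lower number a stronger inhibitor), compound 1 (`CC(C)=CCOc1ccc2c(c1)OC(c1ccccc1Br)CC2=O`) gives 3180 nM as its value. Compound 2 (`CC(C)=CCOc1cc(O)c2c(c1)OC(c1ccc(Cl)cc1Cl)CC2=O`) gives 3340 nM and stands level with compound 1 within the scatter. The next entry in the series is compound 3 (`CC(C)=CCOc1cc(O)c2c(c1)OC(c1ccccc1Br)CC2=O`), which carries 2-bromophenyl in place of 2,4-dichlorophenyl on a saturated ring carbon, next to the ring oxygen (2-bromophenyl in place of 2,4-dichlorophenyl on a saturated ring carbon). Among the compounds with values here, no single-change step between measured compounds is available, so this swap has no direct precedent in the data. With compound 2 at 3340 nM and compound 1 at 3180 nM as the only reference points, no change beyond the scatter is expected in this assay, in either direction. The estimated move is a 1.1-fold lower number from compound 2 to compound 3 (0.05 log units; within the scatter) and counts as no real shift. Compound 3 is expected at 3000 nM in this assay, with an estimated range from 1200 nM to 7500 nM for the measurement.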

Compound 3, half-maximal inhibitory concentration: 3820 nM
Compound 3: middle estimate off by 1.3-fold (0.10 log units), on the low side, within the range that was stated.
By their numbers in this assay, from the lowest: compounds 1, 2 and 3 (each within the scatter of the next).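

In this assay, 2-bromophenyl in place of 2,4-dichlorophenyl on the saturated ring carbon next to the ring oxygen gives a 1.1-fold higher number from compound 2 to compound 3 (0.06 log units; within the scatter) and counts as no real shift, so with the hydroxy group present this position takes either aryl group at a level reading. Hydroxy in place of hydrogen on the aromatic carbon, the first single-change reading of that group, gives a 1.2-fold higher number from compound 1 to compound 3 (0.08 log units; within the scatter) with 2-bromophenyl in place and is also no real shift. No data on hand offer a reason for either result.

As far as these compounds go, whether an amine or a carboxylic acid in place of the aryl ring on that saturated carbon would move the number beyond the scatter stays open. Also open, from the compounds shown here alone, is whether the hydroxy step reads the same with 2,4-dichlorophenyl in place.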